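From ethyl to carbamoyl on a ring nitrogen

The source may hold more compounds than are shown below. What is called first, only, known or untested is meant among the compounds shown, and "the series" means these compounds.

- compound 1 `c1ccc2c(c1)CN[C@@H](CN(CCCN1CCNCC1)[C@H]1CCCc3cccnc31)C2`: 92%
- compound 2 `CCN1CCN(CCCN(C[C@H]2Cc3ccccc3CN2)[C@H]2CCCc3cccnc32)CC1`: 19%

In an ADME assay on microsomes from liver (Mus musculus) for metabolic stability, read by LC-MS, with a stated time of 10 min, tested at 0.5 uM (a lower number here means that less of the compound is left, a higher number that more of the compound is left), compound 2 gives 19% and stands lowest of the two measured compounds. Compound 3 `NC(=O)N1CCN(CCCN(C[C@H]2Cc3ccccc3CN2)[C@H]2CCCc3cccnc32)CC1` has carbamoyl in place of ethyl on an amine nitrogen in a ring. Going by the values given here, one measured step bears on this nitrogen: a number 73 percentage points lower from compound 1 to compound 2 (beyond the scatter), large and beyond the scatter, with ethyl in place of hydrogen. Among the compounds with values here, no carbamoyl compound has been measured, so a large upward step is expected, with wide uncertainty. The expected change is a number 46 percentage points higher from compound 2 to compound 3 (beyond the scatter) by this estimate. The estimated value for compound 3 is 65% (range 35% to 90%).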

Compound 3, percent of the compound remaining: 42%
The estimate for compound 3 lay 23 percentage points above the measured number, within the range that was stated.
By their numbers in this assay, from the lowest: compound 2; then compound 3; then compound 1.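

In this assay carbamoyl on this amine nitrogen in a ring gives back only part of the loss seen with ethyl, with a number 23 percentage points higher from compound 2 to compound 3 (beyond the scatter) and still a number 50 percentage points lower from compound 1 to compound 3 (beyond the scatter). Both substituents therefore stand below the free amine hydrogen, and the choice of substituent at this nitrogen also changes the number. No measurement here accounts for this order of the three compounds. Going by these compounds, it remains open whether a methyl, an acetyl or a longer chain ending in a carboxylic acid at this nitrogen would come closer to compound 1. On these data alone, whether the same order holds on a different core also remains open.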